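A few compounds are considered here, and "the series" means these few. Any claim that something is new, unique, unknown or untested is made for them only; others in the source may bear on it.

Measured so far:
compound 1 `CCCCC(CC)n1ccc2cc(/C(C)=C/C(=O)Nc3ccccc3OCCCC(=O)O)ccc21` — 7.1 nM
compound 2 `C/C(=C\C(=O)Nc1ccccc1OCCCC(=O)O)c1ccc2c(ccn2Cc2cccc(C)c2)c1` — 250 nM
compound 3 `CCCCc1ccc(Cn2ccc3cc(/C(C)=C/C(=O)Nc4ccccc4OCCCC(=O)O)ccc32)cc1` — 100 nM

All three were tested in an assay on Prostate gland for inhibition of steroid 5-alpha-reductase (Rattus norvegicus); on this read-out lower numbers stand for stronger inhibition and higher numbers for weaker inhibition. Compound 3 stands second highest of the three numbers: towards compound 2 there is a 2.5-fold lower number from compound 2 to compound 3 (0.40 log units; beyond the scatter), and towards compound 1 there is a 14-fold higher number from compound 1 to compound 3 (1.15 log units; beyond the scatter), so compound 3 lies much nearer to compound 2 than to compound 1. Compound 4 `C/C(=C\C(=O)Nc1ccccc1OCCCC(=O)O)c1ccc2c(ccn2C(c2ccccc2)C(C)C)c1` has not yet been measured; it differs from compound 3 in one place: 2-methyl-1-phenylpropyl in place of 4-butylbenzyl on an aromatic nitrogen. Among the compounds with values here, two measured steps bear on this change. The step of a 14-fold higher number from compound 1 to compound 3 (1.15 log units; beyond the scatter) shows that exchanging 1-ethylpentyl for 4-butylbenzyl raised the number strongly, and a 35-fold higher number from compound 1 to compound 2 (1.55 log units; beyond the scatter) shows the same for 3-methylbenzyl. The entering 2-methyl-1-phenylpropyl is, like the 1-ethylpentyl of compound 1, not a benzyl group, yet it carries a phenyl ring just as the groups of compounds 2 and 3 do. The number for compound 4 is therefore expected to land between those of compound 3 and compound 1, which means a drop of a 4.0-fold lower number from compound 3 to compound 4 (0.60 log units; beyond the scatter) is expected. For compound 4 the estimate in this assay is 25 nM, with a range from 8 nM to 80 nM.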

Compound 4, half-maximal inhibitory concentration: 25 nM
Estimate against measurement, compound 4: no gap at the digits printed; the measured number falls inside the stated range.
By their numbers in this assay, from the lowest: compound 1; then compound 4; then compound 3; then compound 2.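

In this assay, putting 2-methyl-1-phenylpropyl on the aromatic nitrogen in place of a substituted benzyl group gives a 4.0-fold lower number from compound 3 to compound 4 (0.60 log units; beyond the scatter) and also a 10-fold lower number from compound 2 to compound 4 (1.00 log units; beyond the scatter) and this shows that a phenyl ring at this place does not by itself bring the high numbers of compound 2 and compound 3. Still, 1-ethylpentyl keeps the lowest number of the four, with a 3.5-fold higher number from compound 1 to compound 4 (0.55 log units; beyond the scatter) on going to the group with the ring, and the two lowest numbers belong to the groups with a branch on the carbon bound to the nitrogen. Nothing shown here explains these differences. A 1-phenylethyl or 1-cyclohexyl-2-methylpropyl group would help separate the part played by the branch from that of the phenyl ring. From the compounds shown here alone, whether an amine or a carboxylic acid on this group would be tolerated also stays open.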